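The compounds below may be only part of what the source reports. "The series", "measured", "known", "first", "only" and "open" are said of these compounds alone.

Two compounds of the series carry numbers in an assay on HEK293 cells for inhibition of sodium-dependent dopamine transporter (Homo sapiens); a higher number here means a more potent compound, by a factor of ten per unit of this negative logarithm, a lower number a less potent compound. Compound 2 `O=C(CCCN1CCN(CCCc2ccccc2)CC1)N(Cc1ccccc1)c1ccccc1` gives 7.12 there, and compound 1 `c1ccc(CCCN2CCN(CCN(Cc3ccccc3)c3ccccn3)CC2)cc1` gives 6.91, a gap within the usual scatter, so compound 2 stands level with compound 1 rather than apart from it. Compound 3 `O=C(CCCN1CCN(CCCc2ccccc2)CC1)N(Cc1ccccc1)c1ccccn1` is next to be measured in this assay. The change from compound 2 is pyridin-2-yl in place of phenyl on an amide-type nitrogen. Within the data shown here, no measured pair shows this change, so its step is unknown; the expected step is a number 0.12 log units lower from compound 2 to compound 3 (within the scatter), a size that stays within the scatter in either direction. Compound 3 is accordingly estimated at 7, with a range from 6.4 to 7.6.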

Compound 3, logarithm of the reciprocal of the active concentration, log(1/C): 6.61
Compound 3: middle estimate off by 0.39 log units, on the high side; the range from low to high includes it.
By their numbers in this assay, from the lowest: compounds 3, 1 and 2 (each within the scatter of the next, the first and the last beyond it).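

On the amide-type nitrogen, pyridin-2-yl in place of phenyl gives a number 0.51 log units lower from compound 2 to compound 3 (beyond the scatter) in this assay, so the ring at this position does register in this read-out. The change swaps a carbon-only ring for one with a hetero atom and one hydrogen-bond acceptor, but nothing available ties the step to that difference or explains it.

Still open, from the compounds shown here alone, is how pyridin-3-yl, cyclohexyl or a plain methyl group would read on this nitrogen. Also open, going by these compounds, is whether the step holds with a longer chain on the carbonyl side.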